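The source may hold more compounds than are shown below. What is called first, only, known or untested is meant among the compounds shown, and "the series" means these compounds.

Three compounds have been measured in an assay on isolated protein for inhibition of Rho-associated protein kinase 1 (Homo sapiens), read by scintillation counting, radiometric assay and 33P incorporation, with a stated time of 40 min, in the presence of a further agent that is not named here; a lower number here means a stronger inhibitor, a higher number a weaker inhibitor:

Compound 1, `CC(=O)Nc1cccc(NC(=O)COc2ccc3c(=O)ccoc3c2)c1`, gives 2500 nM.
Compound 2, `O=C(COc1ccc2c(=O)ccoc2c1)Nc1cccc(NC(=O)c2ccccc2)c1`, gives 120 nM.
Compound 3, `CCCc1ccc(C(=O)Nc2cccc(NC(=O)COc3ccc4c(=O)ccoc4c3)c2)cc1`, gives 143 nM.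

Compound 3 stands second of the three; its nearest neighbour is compound 2, with a 1.2-fold higher number from compound 2 to compound 3 (0.08 log units; within the scatter), and its furthest is compound 1, with a 17-fold lower number from compound 1 to compound 3 (1.24 log units; beyond the scatter). The two large steps, a 21-fold lower number from compound 1 to compound 2 (1.32 log units; beyond the scatter) and a 17-fold lower number from compound 1 to compound 3 (1.24 log units; beyond the scatter), both place an aryl group on the carbonyl carbon in place of methyl, while the change on the aromatic carbon from hydrogen to propyl, a 1.2-fold higher number from compound 2 to compound 3 (0.08 log units; within the scatter), lies within the scatter.

Compound 4, `O=C(COc1ccc2c(=O)ccoc2c1)Nc1cccc(NC(=O)c2ccc(Br)cc2)c1`, differs from compound 3 by bromo in place of propyl on an aromatic carbon. Going by the values given here, no measured step replaces propyl with bromo, and the only step touching this aromatic carbon, a 1.2-fold higher number from compound 2 to compound 3 (0.08 log units; within the scatter), is within the scatter; the carbonyl-bound phenyl present in both large steps is kept. Compound 4 is therefore expected to land close to compound 3 in this assay. The step is expected to be a 1.1-fold lower number from compound 3 to compound 4 (0.04 log units; within the scatter), within the scatter. Compound 4 is estimated at 130 nM, with a range of 50 nM to 350 nM.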

Compound 4, half-maximal inhibitory concentration: 303 nM
Beside the measured number, compound 4's estimate is 2.3-fold (0.37 log units) below it, within the range that was stated.
By their numbers in this assay, from the lowest: compounds 2 and 3 (each within the scatter of the next); then compound 4; then compound 1.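

In this assay, going by these compounds alone, the earlier compounds showed only one change at this aromatic carbon, hydrogen to propyl, and that change lay within the scatter, so the position could have seemed indifferent to its substituent. Bromo shows that it is not: this group on the same carbon gives a step beyond the scatter against hydrogen (a 2.5-fold higher number from compound 2 to compound 4 (0.40 log units; beyond the scatter)) and against propyl (a 2.1-fold higher number from compound 3 to compound 4 (0.33 log units; beyond the scatter)). The aryl gain over methyl persists with 4-bromophenyl on the carbonyl carbon, but only as a modest step (an 8.3-fold lower number from compound 1 to compound 4 (0.92 log units; beyond the scatter)).

No evidence is available here to explain why bromo and propyl differ at this carbon. Going by these compounds, whether chloro, methoxy, an amine, a carboxylic acid or a longer chain at this carbon would track with propyl or with bromo remains open.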